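The compounds below may be only part of what the source reports. "The series", "measured", "known", "first", "only" and "open" are said of these compounds alone.

Compound 1 `O=C(NCCCCC(c1ccc(F)cc1)c1ccc(F)cc1)Nc1ccc(I)cc1` is a urea that sits at the weaker end of the two numbers shown. In a functional assay on MDA-MB-231 cells (Homo sapiens) for cytotoxicity, read by MTT assay, with a stated time of 48 h (on this read-out lower numbers stand for stronger inhibition and higher numbers for weaker inhibition), compound 1 gives 11800 nM. Its nearest neighbour among the measured values is compound 3 `O=C(NCCCCCC(c1ccc(F)cc1)c1ccc(F)cc1)Nc1ccc(Cl)c(C(F)(F)F)c1`, which carries the same chloro- and trifluoromethyl-bearing aryl on a longer chain and in this assay gives 2570 nM, a lower number that lies beyond the scatter. Compound 2 `O=C(NCCCCN(c1ccc(F)cc1)c1ccc(F)cc1)Nc1ccc(I)cc1`, in which a nitrogen replaces the methine bearing the two fluorophenyl groups, reaches only a limit: in this assay compound 2 gives > 20000 nM, and the fact that it is a limit is shown by the limit of > 20000 nM in this assay, at which 1 of the 3 values shown sits.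

The step considered here leads to compound 4 `O=C(NCCCCC(c1ccc(F)cc1)c1ccc(F)cc1)c1ccc(Cl)c(C(F)(F)F)c1`. The change is 4-chloro-3-(trifluoromethyl)phenyl in place of (4-iodophenyl)amino on a carbonyl carbon. Among the measured compounds shown here, with no measured pair separating a urea from an amide here, the size of this step is open; the expectation rests on compound 3, whose value of 2570 nM shows the entering aryl on a close relative at a lower number than compound 1. A modest move toward a lower number is therefore expected, though a result within the scatter would not surprise. For compound 4 the estimate is 6000 nM, between 2000 nM and 18000 nM, which means an expected step of a 2.0-fold lower number from compound 1 to compound 4 (0.29 log units; within the scatter).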

Compound 4, half-maximal inhibitory concentration: 11700 nM
For compound 4 the middle estimate is 2.0-fold (0.29 log units) below the measured one, and the stated range covers the measured number.
By their numbers in this assay, from the lowest: compound 3; then compounds 4 and 1 (each within the scatter of the next). At a limit, above all of these: compound 2.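

In this assay the step is a 1.0-fold lower number from compound 1 to compound 4 (0.00 log units; within the scatter), so at this place on the carbonyl carbon the exchange of (4-iodophenyl)amino for 4-chloro-3-(trifluoromethyl)phenyl leaves the number unmoved. This is the first pair shown that differs in one place only, and it shows that the core of compound 1 keeps its number in this assay when the urea becomes an amide, with the nitrogen and its hydrogen-bond donor gone and a different aryl in place. The evidence at hand offers nothing that bears on why the two numbers stay together.

Among the compounds shown here, the one step joins the loss of the nitrogen with the change of aryl, so the share of each stays unknown, and compound 3 differs from compound 4 in more than one place, so those two cannot be set against each other. Open too, as far as these compounds go, is what a longer chain would do on the amide of compound 4, and whether a sulfonamide or an amine in place of the carbonyl would hold the number at this position.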